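The source may hold more compounds than are shown below. What is called first, only, known or untested is meant among the compounds shown, and "the series" means these compounds.

The series consists of anilides that carry a trifluoromethyl group and a pyridyl amide. Compound 3 `CCN(CC)c1ccc(C(F)(F)F)cc1NC(=O)c1ccncc1` bears diethylamino on the aromatic ring and a pyridin-4-yl on the carbonyl carbon; in a functional assay on HL-60 cells (Homo sapiens) for cytotoxicity, read by MTT assay, with a stated time of 48 h (a lower number here means a stronger inhibitor, a higher number a weaker inhibitor), compound 3 gives 89700 nM. Compound 1 `CCN(CC)c1ccc(C(F)(F)F)cc1NC(=O)c1cccnc1` differs from it only by pyridin-3-yl in place of pyridin-4-yl on a carbonyl carbon; in this assay compound 1 gives 71000 nM. The step of a 1.3-fold lower number from compound 3 to compound 1 (0.10 log units; within the scatter) lies within the scatter, so the two cannot be told apart on this evidence. Compound 2 `O=C(Nc1cc(C(F)(F)F)ccc1N1CCCC1)c1ccncc1` differs from compound 3 by pyrrolidin-1-yl in place of diethylamino on an aromatic carbon; in this assay compound 2 is recorded as "not active" (no number reported), with no number attached to it. Compound 4 `O=C(Nc1cc(C(F)(F)F)ccc1N1CCCC1)c1cccnc1` has not yet been measured; it differs from compound 2 by pyridin-3-yl in place of pyridin-4-yl on a carbonyl carbon, the same change that separates compound 3 from compound 1, occurring twice among these four compounds, and the place of the change reads the same in both cases. Since that change produced a 1.3-fold lower number from compound 3 to compound 1 (0.10 log units; within the scatter), a step of similarly small size, within the scatter, is expected from compound 2 to compound 4 in this assay, resting on that single measured pair. Compound 2 gave no number, and compounds 1 and 3 both sit at high concentrations. Compound 4 is therefore expected to give 100000 nM in this assay, within an estimated range from 40000 nM to 250000 nM, with a considerable chance that only an inactive report results.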

Compound 4, half-maximal inhibitory concentration: "not active" (no number reported)
Compound 4: no number reported; there is nothing to compare the estimate with.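

Going by these compounds alone, compound 2 and compound 4 are both reported as inactive without a number in this assay so no step between them can be read. No available evidence bears on this result. The compounds shown leave open whether pyridin-3-yl in place of pyridin-4-yl changes anything when pyrrolidin-1-yl is present, and how far pyrrolidin-1-yl in place of diethylamino shifts the activity.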